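Swapping the formyl group on a shared core

The source may hold more compounds than are shown below. What is called first, only, known or untested is meant among the compounds shown, and "the series" means these compounds.

Measured compounds:
- compound 1 `O=Cc1ccc(-c2cn3ccnc3c(-c3ccc4ncn(C5CCCCC5)c4c3)n2)cc1` — 92.6%
- compound 2 `CC(=O)c1ccc(-c2cn3ccnc3c(-c3ccc4ncn(C5CCCCC5)c4c3)n2)cc1` — 15.9%
- compound 3 `Fc1ccccc1-c1cn2ccnc2c(-c2ccc3ncn(C4CCCCC4)c3c2)n1` — 25.8%

Three compounds built on one shared core were tested in a functional assay on HCT-116 cells (Homo sapiens) for inhibition, read by sulforhodamine B assay, with a stated time of 48 h, tested at 10 uM; on this read-out lower numbers stand for less inhibition and higher numbers for more inhibition at the one concentration tested (going by the name of the read-out). Compound 1 stands highest of the three, with the nearest of the others well below it. Both of the other two sit low: compound 2 gives 15.9% and compound 3 gives 25.8% in this assay, and these two differ only within the usual scatter, as shown by a number 9.9 percentage points higher from compound 2 to compound 3 (within the scatter).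

The new compound 4 `FC(F)(F)c1cccc(-c2cn3ccnc3c(-c3ccc4ncn(C5CCCCC5)c4c3)n2)c1` differs from compound 1 in a single place: 3-(trifluoromethyl)phenyl in place of 4-formylphenyl on an aromatic carbon.

Within the data shown here, two measured steps bear on this change. Moving from the formyl group to an acetyl group costs a great deal, a number 76.7 percentage points lower from compound 1 to compound 2 (beyond the scatter). Replacing the 4-formylphenyl by a 2-fluorophenyl, a change that also removes the hydrogen-bond acceptor, costs almost as much, a number 66.8 percentage points lower from compound 1 to compound 3 (beyond the scatter). Compound 4 likewise loses the formyl group and its acceptor, so a large drop is expected, a number 67.6 percentage points lower from compound 1 to compound 4 (beyond the scatter).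

Compound 4 is therefore estimated at 25% in this assay, with a likely range from 5% to 55%.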

Compound 4, a percentage reported as inhibition, at one concentration (the size of the read-out at that concentration, not a potency): 17.6%
Estimate against measurement, compound 4: 7.4 percentage points above; low and high end bracket the measured number.
By their numbers in this assay, from the lowest: compounds 2, 4 and 3 (each within the scatter of the next); then compound 1.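

In this assay, the change to 3-(trifluoromethyl)phenyl gives a number 75 percentage points lower from compound 1 to compound 4 (beyond the scatter), so a third, quite different replacement for the 4-formylphenyl group also ends far below compound 1. The low numbers now form a tight group, with a number 8.2 percentage points lower from compound 3 to compound 4 (within the scatter) and a number 1.7 percentage points higher from compound 2 to compound 4 (within the scatter), both within the scatter. At this aromatic carbon, then, the 4-acetylphenyl, 2-fluorophenyl and 3-(trifluoromethyl)phenyl groups cannot be told apart, and among these four compounds only the 4-formylphenyl group of compound 1 stands clear of the rest, though no measurement shown here explains why.

Going by these compounds, what stays open is whether the high number needs the formyl group itself or whether another group on the same phenyl ring, such as a nitrile, a carboxylic acid or a hydroxymethyl group, could match it. The read-out at a single concentration also leaves open whether compounds 2, 3 and 4 would separate from one another at other concentrations, and how far compound 1 stands from them in true potency.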